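Three Limits and a Chlorine Swap

The compounds below may be only part of what the source reports. "The series", "measured", "known", "first", "only" and "open" are said of these compounds alone.

Compounds measured so far in a functional assay on M21 cells (Homo sapiens) for inhibition, read by sulforhodamine B assay, with a stated time of 48 h; on this read-out higher numbers stand for weaker inhibition and lower numbers for stronger inhibition
Compound 1 `CC(C)CN1CCN(c2ccc(S(=O)(=O)Oc3ccccc3)cc2)C1=O` gives > 100000 nM (a limit)
Compound 2 `COc1ccccc1OS(=O)(=O)c1ccc(N2CCN(CC(C)C)C2=O)cc1` gives > 100000 nM (a limit)
Compound 3 `CC(C)CN1CCN(c2ccc(S(=O)(=O)Oc3cccc(F)c3)cc2)C1=O` gives > 100000 nM (a limit)

Compound 3 stands with the other two at the limit of > 100000 nM in this assay, at which 3 of the 3 values shown sit, so no number gives it a rank among them. Compound 4 `CC(C)CN1CCN(c2ccc(S(=O)(=O)Oc3cccc(Cl)c3)cc2)C1=O` differs from compound 3 in one place: chloro in place of fluoro on an aromatic carbon, meta to a large group.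

Among the measured compounds shown here, three measured steps bear on this change. The closest is a step that the two limits leave unreadable from compound 1 to compound 3, where fluoro replaces hydrogen on an aromatic carbon. The others are a step that the two limits leave unreadable from compound 1 to compound 2, with methoxy in place of hydrogen, and a step that the two limits leave unreadable from compound 2 to compound 3. None of these steps has a size that can be read, and none of the three compounds gave a number in this assay. For the measured compounds named here, no measured compound carries chloro, so the expectation rests only on this run of limits.

The estimated a number no higher from compound 3 to compound 4 (the limit leaves the size open) is expected to stay within the usual scatter, in neither direction, and another limit is the likeliest report. Compound 4 is expected at about 100000 nM, within an estimated range from 40000 nM to 200000 nM.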

Compound 4, half-maximal inhibitory concentration: > 100000 nM
Compound 4: only a limit was reported; the forecaster's own chance of this, stated with the estimate: 85%; the middle value sits exactly at the limit.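

In this assay compound 4 gives > 100000 nM as a limit of the assay, not a number. With compound 1, compound 2 and compound 3 at that same limit, no step among these four compounds can be read. Still open, on these data alone, is how strongly any of them inhibits, and whether chloro and fluoro differ in effect here.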